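Swapping a Pentyl Chain for an Ethoxyethyl Chain

The source may hold more compounds than are shown below. What is called first, only, known or untested is meant among the compounds shown, and "the series" means these compounds.

Of the compounds shown here, three built on one shared core have been measured in an assay on HEK293 cells for inhibition of acid ceramidase (Homo sapiens), read by fluorescence, with stated times of 10 min and 3 h; on this read-out lower numbers stand for stronger inhibition and higher numbers for weaker inhibition. Compound 1 `O=C(NCCCCc1ccccc1)n1c(=O)oc2cnccc21` gives 3 nM. Compound 2 `CCOCCNC(=O)n1c(=O)oc2cc(C3CCN(C)CC3)ccc21` gives 1050 nM. Compound 3 `CCCCCNC(=O)n1c(=O)oc2cc(-c3ccc(F)cc3)ccc21` gives 60 nM, the second highest of the three numbers; its gap to compound 2 and its gap to compound 1 both lie beyond the usual scatter of repeated measurements, so compound 3 sits clearly between the other two.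

Compound 4 `CCOCCNC(=O)n1c(=O)oc2cc(-c3ccc(F)cc3)ccc21` has not yet been measured. It differs from compound 3 in a single place: ethoxy in place of propyl on a saturated chain carbon, two bonds along the chain from an amide-type nitrogen. Put another way, the pentylamino group of compound 3 becomes a (2-ethoxyethyl)amino group. Among the measured compounds shown here, no measured pair isolates this change on its own. Compound 2 carries the same (2-ethoxyethyl)amino group and gives 1050 nM, but it also differs from compound 3 elsewhere in the molecule, so it offers a hint rather than a clean comparison. On that hint, the expected change, a 2.5-fold higher number from compound 3 to compound 4 (0.40 log units; beyond the scatter), is a modest rise in the number, a weakening somewhat beyond the scatter. Compound 4 is therefore estimated at 150 nM, with a likely range from 50 nM to 500 nM.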

Compound 4, half-maximal inhibitory concentration: 2300 nM
Estimate against measurement, compound 4: 15-fold (1.19 log units) below, and the stated range ends below it.
By their numbers in this assay, from the lowest: compound 1; then compound 3; then compound 2; then compound 4.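

In this assay, with the 4-fluorophenyl group held fixed, ethoxy in place of propyl keeps the count of 3 heavy atoms but swaps one carbon for an oxygen and adds a hydrogen-bond acceptor, and this single change brings a 38-fold higher number from compound 3 to compound 4 (1.58 log units; beyond the scatter). This is a large step, so this place on the chain tolerates the change poorly. Compound 2 alone could only hint at this, and it also differs from compound 3 on an aromatic carbon. With the (2-ethoxyethyl)amino group held fixed, 4-fluorophenyl in place of 1-methylpiperidin-4-yl brings only a 2.2-fold higher number from compound 2 to compound 4 (0.34 log units; beyond the scatter), a modest step, and nothing available explains why either step has the size it has.

As far as these compounds go, what remains open is whether the large step belongs to an oxygen at this exact place on the chain, or would also appear with a 3-methoxypropyl chain or with an amine on the chain instead. A pentyl chain paired with the 1-methylpiperidin-4-yl group would show whether the aromatic-carbon step keeps its modest size when the chain holds no oxygen.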